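Benzyl aryl exchange on the shared core: compound 4

This account rests on a few compounds, and the source may have more. Where it says the series, first, only, none or still open, it means among the compounds named here.

The three measured compounds share a core bearing an ester-linked alkene and a benzyl group on the ring nitrogen. In a functional assay on HT-29 cells (Homo sapiens) for cytotoxicity, read by MTT assay, with a stated time of 48 h (on this read-out lower numbers stand for stronger inhibition and higher numbers for weaker inhibition), compound 1 `CC(C)(C)OC(=O)/C=C/c1ccc2c(c1)C(=O)C(=O)N2Cc1ccc(Br)cc1` gives 730 nM. Compound 2 `COC(=O)/C=C/c1ccc2c(c1)C(=O)C(=O)N2Cc1ccc(Cl)c(Cl)c1` gives 210 nM in this assay, the lowest of the three numbers; the nearest other value is that of compound 1 and the furthest is that of compound 3, both beyond the scatter. Compound 3 `COC(=O)/C=C/c1cccc2c1C(=O)C(=O)N2Cc1ccc(OC)cc1` gives 3120 nM in this assay.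

Compound 4 `COC(=O)/C=C/c1ccc2c(c1)C(=O)C(=O)N2Cc1ccc(C#N)cc1` differs from compound 2 in one place: 4-cyanophenyl in place of 3,4-dichlorophenyl on a saturated chain carbon bound to an amide-type nitrogen in a ring. Among the measured compounds shown here, no pair of measured compounds differs in just this way, so no measured step isolates such an exchange; compound 1 and compound 2 differ in more than one place, and their values show only that the dichloro-bearing compound 2 has the lower number.

The step from compound 2 to compound 4 in this assay is expected to be moderate and upward, toward weaker inhibition, a 2.9-fold higher number from compound 2 to compound 4 (0.46 log units; beyond the scatter). Compound 4 is estimated at 600 nM in this assay, within 200 nM to 2000 nM.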

Compound 4, half-maximal inhibitory concentration: 50 nM
For compound 4 the middle estimate is 12-fold (1.08 log units) above the measured one, outside the stated range (below it).
By their numbers in this assay, from the lowest: compound 4; then compound 2; then compound 1; then compound 3.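

Among the compounds shown here, the exchange of 3,4-dichlorophenyl for 4-cyanophenyl, on a saturated chain carbon bound to an amide-type nitrogen in a ring, gives the first single-place step: a 4.2-fold lower number from compound 2 to compound 4 (0.62 log units; beyond the scatter) in this assay and beyond the scatter. In this comparison, the two chlorines of compound 2 are not required for a low number, and a nitrile-bearing aryl group of the same heavy-atom count goes further in the direction of stronger inhibition. No measurement at hand bears on why the number falls.

The compounds shown do not separate the contribution of the entering nitrile from that of losing the chlorines. Going by these compounds, how 4-aminophenyl or 4-carboxyphenyl would behave at this place remains open, as does whether the step carries over to other esters, such as a tert-butyl ester.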